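This account rests on a few compounds, and the source may have more. Where it says the series, first, only, none or still open, it means among the compounds named here.

Compound 1 `Nc1ccccc1NC(=O)c1ccc(CSC(=S)N2CCN(c3ccccc3)CC2)cc1`: 62.2%
Compound 2 `Nc1ccccc1NC(=O)c1ccc(CSC(=S)N2CCc3ccccc32)cc1`: 38%
Compound 3 `CC1CCCCN1C(=S)SCc1ccc(C(=O)Nc2ccccc2N)cc1`: 45.5%

These three compounds were measured in a functional assay on HeLa cells (Homo sapiens) for antiproliferative activity, read by CCK-8 assay, with a stated time of 72 h, tested at 2 uM; a higher number here means a stronger effect of the compound at the concentration tested, a lower number a weaker effect. Compound 1 gives the highest of the three numbers; compound 3 lies lower, beyond the scatter, and compound 2 lies lower still, also beyond the scatter. Among the measured compounds shown here, the single step between compounds that differ in one place, a number 7.5 percentage points higher from compound 2 to compound 3 (within the scatter), lies within the scatter. Compound 4 `N#Cc1ccc(N2CCN(C(=S)SCc3ccc(C(=O)Nc4ccccc4N)cc3)CC2)cc1` differs from compound 1 by cyano in place of hydrogen on an aromatic carbon. For the measured compounds named here, no measured step touches this part of the shared core; the step from compound 2 to compound 3 alters the group on the thiocarbonyl carbon and so does not bear on this change. With nothing to draw on, no movement beyond the scatter is expected in this assay. Compound 4 is therefore estimated at 62%, within 42% to 80%, a step of a number 0.2 percentage points lower from compound 1 to compound 4 (within the scatter) that is expected to stay within the scatter.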

Compound 4, a percentage reported as inhibition, at one concentration (the size of the read-out at that concentration, not a potency): 71.6%
Estimate against measurement, compound 4: 9.6 percentage points below; low and high end bracket the measured number.
By their numbers in this assay, from the lowest: compounds 2 and 3 (each within the scatter of the next); then compounds 1 and 4 (each within the scatter of the next).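

In this assay, among the compounds shown here, the change from phenyl to 4-cyanophenyl gives a number 9.4 percentage points higher from compound 1 to compound 4 (within the scatter), the first reading at this position of the shared core. Cyano in place of hydrogen on this aromatic carbon, para to a large group, therefore leaves the number within the scatter. Nothing measured here offers an explanation for this result.

On these data alone, whether an amine or a carboxylic acid on that carbon would also stay within the scatter remains open. So does the effect of cyano on the groups carried by compound 2 and compound 3.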